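Flipping One Stereocentre in a Short-Lived Compound

The source may hold more compounds than are shown below. What is called first, only, known or untested is meant among the compounds shown, and "the series" means these compounds.

Compound 1 `CC(C)[C@H](C[C@H]1CCNC1=O)c1ccc(-c2ccc3cccc(F)c3c2)[nH]c1=O` was tested in an ADME assay on microsomes from liver (Homo sapiens) for metabolic stability (a higher number here means that the compound lasts longer, a lower number that the compound disappears faster), and gave 0.257 h. That is the lower of the two half-lives measured here; the other compound, compound 2 `CCn1ncc2c(F)cc(-c3ccc(C(CC)(CC)c4nnc[nH]4)c(=O)[nH]3)cc21`, lasts considerably longer, since compound 2 gives 2.7 h in this assay. The two compounds have little in common structurally, so this gap does not reveal what any single change does.

Compound 3 `CC(C)[C@@H](C[C@H]1CCNC1=O)c1ccc(-c2ccc3cccc(F)c3c2)[nH]c1=O` is a close relative of compound 1: the two compounds have the same atoms and bonds and differ only in configuration as drawn: 1 of 2 stereo elements differ; a stereocentre at a saturated chain carbon is drawn S in compound 1 and R in compound 3. Nothing is added and nothing is removed; only the spatial arrangement at that one carbon is different. Among the compounds with values here, no measured pair in this set shows what such a change does in this assay. A change at a single stereocentre can leave the half-life as it is or move it in either direction, and without a comparable pair there is no basis to expect a move beyond the scatter. The expected change is therefore small: a 1.2-fold higher number from compound 1 to compound 3 (0.07 log units; within the scatter). Compound 3 is estimated to give 0.3 h in this assay, with a plausible range from 0.12 h to 0.8 h.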

Compound 3, half-life in the Homo sapiens assay: 0.693 h
Compound 3: middle estimate off by 2.3-fold (0.36 log units), on the low side, and the stated range covers the measured number.
By their numbers in the Homo sapiens assay, from the lowest: compound 1; then compound 3; then compound 2.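

Within the data shown here, in the Homo sapiens assay, turning the saturated chain carbon from S to R gives a 2.7-fold higher number from compound 1 to compound 3 (0.43 log units; beyond the scatter), the first comparison here that isolates a single change, and it shows that the spatial arrangement at this one carbon can move the half-life beyond the scatter. Nothing but this arrangement separates the two compounds, so the step can be tied to this carbon alone because of the following: the fact that compounds 1 and 3 differ only in the configuration as drawn In a physicochemical assay for solubility, in phosphate buffer, measured as kinetic solubility (a higher number here means a more soluble compound, a lower number a less soluble compound), compound 1 gives 26800 nM and compound 3 gives 32000 nM, two numbers within the scatter of each other, so this pair shows the longer half-life of the R form without a solubility difference that can be told from the scatter.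

The pair does not say why the R form lasts longer, nor what the second stereo element, drawn the same in compound 1 and compound 3, contributes. It also leaves open whether the R form would keep its longer half-life with a different group on this carbon, such as a longer chain, an amine or a carboxylic acid.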